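Chloro in Place of Nitro, with Only Limits to Go On

The compounds below may be only part of what the source reports. "The series", "measured", "known", "first", "only" and "open" are said of these compounds alone.

Compound 1 `O=C(/C=C/c1ccc2c(c1)B(O)OC2)c1ccc([N+](=O)[O-])cc1` is tested in an ADME assay on L929 cells (Mus musculus) for cytotoxicity, read by resazurin assay, with a stated time of 72 h; a higher number here means a weaker inhibitor, a lower number a stronger inhibitor. In this assay compound 1 gives > 10 ug/mL, which is a limit of the assay and not a number. Compound 2 `COc1cc(C(=O)/C=C/c2ccc3c(c2)B(O)OC3)ccc1[N+](=O)[O-]` carries a methoxy in place of hydrogen on an aromatic carbon, and in this assay compound 2 gives > 10 ug/mL, again a limit. Compound 3 `COc1cccc(C(=O)/C=C/c2ccc3c(c2)B(O)OC3)c1` carries hydrogen in place of nitro on an aromatic carbon, and in this assay compound 3 gives > 10 ug/mL, also a limit. The step that the two limits leave unreadable from compound 1 to compound 2 and the step that the two limits leave unreadable from compound 2 to compound 3 therefore carry no readable size, because of the limit of > 10 ug/mL in this assay, at which 3 of the 3 values shown sit. Compound 4 `O=C(/C=C/c1ccc2c(c1)B(O)OC2)c1ccc(Cl)cc1` has not yet been measured and differs from compound 1 by chloro in place of nitro on an aromatic carbon. Of the measured steps, the change from compound 2 to compound 3, hydrogen in place of nitro on an aromatic carbon, is the one that touches the nitro, and it left a limit on both sides. No step beyond the scatter is expected in this assay. Compound 4 is therefore expected to give 20 ug/mL, in a range from 8 ug/mL to 60 ug/mL. The step that the limit leaves unreadable from compound 1 to compound 4 is estimated to stay within the scatter.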

Compound 4, half-maximal inhibitory concentration: > 10 ug/mL
Compound 4 was reported as a limit; the forecaster's own chance of this, stated with the estimate: 75%; the middle value does not contradict the limit.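

Compound 1 and compound 4 both stand at a limit in this assay, so no size can be read for the change from nitro to chloro: the limit of > 10 ug/mL in this assay, at which 4 of the 4 values shown sit. The compounds shown leave open whether any change on the shared core shifts the read-out at all.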